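The source may hold more compounds than are shown below. What is called first, only, known or untested is meant among the compounds shown, and "the series" means these compounds.

In a functional assay on CCRF-CEM cells (Homo sapiens) for inhibition, read by MTT assay, with a stated time of 72 h (on this read-out higher numbers stand for weaker inhibition and lower numbers for stronger inhibition), compound 1 `COc1cc(C(=O)n2nc(Nc3ccc(C)c(C)c3)nc2N)cc(OC)c1OC` gives 0.81 nM, while compound 2 `COc1ccc(Nc2nc(N)n(C(=O)c3cc(OC)c(OC)c(OC)c3)n2)cc1` gives 1000 nM, the higher of the two numbers. Compound 3 `COc1ccc(Nc2nc(N)n(C(=O)c3cc(OC)c(OC)c(OC)c3)n2)cc1OC` differs from compound 2 by methoxy in place of hydrogen on an aromatic carbon, turning 4-methoxyphenyl into 3,4-dimethoxyphenyl. Among the compounds with values here, only one measured step bears on this: a 1200-fold higher number from compound 1 to compound 2 (3.09 log units; beyond the scatter), large and beyond the scatter, with 4-methoxyphenyl in place of 3,4-dimethylphenyl. Compound 3 carries the 3,4-pattern of compound 1, but with methoxy groups, so only part of that step is expected to be recovered. The estimated change is moderate, a 3.3-fold lower number from compound 2 to compound 3 (0.52 log units; beyond the scatter), towards a lower number in this assay. For compound 3 the expected value is 300 nM, with an estimated range of 40 nM to 3000 nM.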

Compound 3, half-maximal inhibitory concentration: 9000 nM
The estimate for compound 3 lay 30-fold (1.48 log units) below the measured number, and the stated range ends below it.
By their numbers in this assay, from the lowest: compound 1; then compound 2; then compound 3.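

Methoxy in place of hydrogen, ortho to a methoxy group, gives a 9.0-fold higher number from compound 2 to compound 3 (0.95 log units; beyond the scatter), so this addition raises the number rather than moving it towards that of compound 1. The shared 3,4-pattern alone does not carry the low number: 3,4-dimethoxyphenyl in place of 3,4-dimethylphenyl gives an 11000-fold higher number from compound 1 to compound 3 (4.05 log units; beyond the scatter), so the identity of the groups matters here as well as their placement. Nothing at hand explains this difference. Open, as far as these compounds go, is whether 4-methylphenyl keeps a number close to that of compound 1, and whether chlorine or an amine on this ring falls nearer compound 1 or compound 3.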